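A few compounds are considered here, and "the series" means these few. Any claim that something is new, unique, unknown or untested is made for them only; others in the source may bear on it.

Measured compounds:
compound 1 `CCn1c(SCC(=O)Nc2ccc(/C(C)=N/O)cc2)nnc1-c1ccc(OC)c(OC)c1`, which in a functional assay on the whole organism (strain albino) for inhibition, with Rattus norvegicus as the target, read by paw edema, with stated times of 30 min and 2 h, at a dose of 0.28 mmol/kg by the oral route (on this read-out higher numbers stand for more inhibition at the one dose given (going by the name of the read-out) and lower numbers for less inhibition), gives 65%
compound 2 `COc1ccc(-c2nnc(SCC(=O)Nc3ccc(/C(C)=N/O)cc3)n2-c2ccccc2)cc1OC`, which in this assay gives 63%
compound 3 `C=CCn1c(SCC(=O)Nc2ccc(C(C)=O)cc2)nnc1-c1ccc(OC)c(OC)c1`, which in this assay gives 57%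

Compound 3 stands lowest of the three numbers; its nearest neighbour is compound 2, its furthest compound 1, and both gaps lie within the usual scatter. Compound 4 `C=CCn1c(SCC(=O)Nc2ccc(/C(C)=N/O)cc2)nnc1-c1ccc(OC)c(OC)c1` differs from compound 3 in one place: a group of 4 heavy atoms (2 carbon, 1 nitrogen, 1 oxygen; no ring) in place of a group of 3 heavy atoms (2 carbon, 1 oxygen; no ring), on an aromatic carbon. Among the compounds with values here, the only measured step, a number 2 percentage points lower from compound 1 to compound 2 (within the scatter), concerns a different part of the shared core, so no step directly mirrors this change. Compounds 1 and 2, which carry the entering group, sit slightly higher than compound 3, which carries the leaving group, but within the scatter. A small rise, or none beyond the scatter, is therefore expected for compound 4, namely a number 5 percentage points higher from compound 3 to compound 4 (within the scatter). Compound 4 is estimated at 62%, with a range from 50% to 74%.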

Compound 4, a percentage reported as inhibition, in the whole organism at one dose (the size of the read-out at that dose, not a potency): 56%
Beside the measured number, compound 4's estimate is 6 percentage points above it; the range from low to high includes it.
By their numbers in this assay, from the lowest: compounds 4, 3, 2 and 1 (each within the scatter of the next).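

With allyl on the aromatic nitrogen, the group of 4 heavy atoms in place of acetyl on the aromatic carbon gives a number 1 percentage points lower from compound 3 to compound 4 (within the scatter) in this assay, so this change, which adds a hydrogen-bond donor, has no readable effect here. Allyl in place of phenyl gives a number 7 percentage points lower from compound 2 to compound 4 (within the scatter), and allyl in place of ethyl gives a number 9 percentage points lower from compound 1 to compound 4 (within the scatter), so these three nitrogen groups cannot be told apart. No measurement shown offers an explanation for these results. Open, going by these compounds, is what a carboxylic acid or an amine would do on that aromatic carbon, and what a longer chain would do on the aromatic nitrogen.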